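A few compounds are considered here, and "the series" means these few. Any claim that something is new, unique, unknown or untested is made for them only; others in the source may bear on it.

Compound 2 `CN(C)C(=O)N1CCC[C@H]1C(=O)N1CCC(NS(=O)(=O)c2cc(S(=O)(=O)c3ccccc3)ccc2C(F)(F)F)CC1` is a urea: its five-membered ring nitrogen carries a dimethylcarbamoyl group. Going by the values given here, in an assay on isolated protein for binding affinity to secreted frizzled-related protein 1 (Homo sapiens), read by fluorescence (a higher number here means a weaker inhibitor, a lower number a stronger inhibitor), compound 2 gives 30 nM, the lowest of the two numbers measured so far. Its nearest neighbour is compound 1 `CN(C)c1ccc(C(=O)N2CCC[C@H]2C(=O)N2CCC(NS(=O)(=O)c3cc(S(=O)(=O)c4ccccc4)ccc3C(F)(F)F)CC2)cc1`, which differs only at the carbonyl carbon, where a 4-(dimethylamino)phenyl group sits instead of a dimethylamino group; in this assay compound 1 gives 110 nM. That single change, a 3.7-fold lower number from compound 1 to compound 2 (0.56 log units; beyond the scatter), shows the part attached to the carbonyl matters, yet it keeps the carbonyl in place.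

Compound 3 `CC(C)(C)CCN1CCC[C@H]1C(=O)N1CCC(NS(=O)(=O)c2cc(S(=O)(=O)c3ccccc3)ccc2C(F)(F)F)CC1` goes further: 3,3-dimethylbutyl in place of dimethylcarbamoyl on an amine nitrogen in a ring. The carbonyl and its acceptor leave altogether and a plain six-carbon chain takes their place. Among the compounds with values here, no measured step tests a change of this kind, so the measured step from compound 1 to compound 2 offers only a weak guide. A modest loss seems the most likely outcome, though a result within the scatter cannot be ruled out. Compound 3 is therefore expected to give about 70 nM in this assay, somewhere between 15 nM and 300 nM, which would mean an expected step of a 2.3-fold higher number from compound 2 to compound 3 (0.37 log units; beyond the scatter).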

Compound 3, half-maximal inhibitory concentration: 30 nM
The estimate for compound 3 lay 2.3-fold (0.37 log units) above the measured number; the measured number falls inside the stated range.
By their numbers in this assay, from the lowest: compounds 2 and 3 (each within the scatter of the next); then compound 1.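

In this assay the swap at this position gives no change at the digits printed from compound 2 to compound 3 (within the scatter), so on this amine nitrogen in a ring, dimethylcarbamoyl, with its carbonyl and its hydrogen-bond acceptor, can be replaced by 3,3-dimethylbutyl, which has no hydrogen-bond acceptor, with no difference beyond the scatter. The carbonyl present in both compound 1 and compound 2 is therefore not needed here to reach a number of this size, and the other new step, a 3.7-fold lower number from compound 1 to compound 3 (0.56 log units; beyond the scatter), is the same size as the step seen earlier with the urea. Nothing available here offers an explanation for this result.

With only three groups shown on this nitrogen, it remains open whether a shorter chain such as ethyl, a ring-bearing group such as cyclohexylmethyl, or the bare nitrogen with just a hydrogen would hold the number at this level. From the compounds shown here alone, it is also open whether a chain ending in an amine or a carboxylic acid would be accepted as readily as the 3,3-dimethylbutyl group.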